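A few compounds are considered here, and "the series" means these few. Any claim that something is new, unique, unknown or untested is made for them only; others in the source may bear on it.

Working notes on the series. Compound 1 `O=CN(O)C(CCc1ncccn1)CS(=O)(=O)N1CCN(c2ccc(Cl)cn2)CC1` is known only to a limit: in an ADME assay for inhibition of Bile salt export pump (Homo sapiens), read by scintillation counting, with a stated time of 5 min (a lower number here means a stronger inhibitor, a higher number a weaker inhibitor), compound 1 gives < 10000 nM, a limit of the assay rather than a number. Compound 2 `CC(C)(C)c1cc(C(C)(C)C)c2oc(C(=O)O)cc(=O)c2c1` also reaches only a limit, giving < 10000 nM in this assay. Compound 3 `CC(=O)NC[C@H]1CN(c2cc(F)c(C3=CCN(C(=O)CO)CC3)c(F)c2)C(=O)O1` sits at a limit as well, with > 1000000 nM in this assay. Within the data shown here, two of the three values thus share the limit of < 10000 nM in this assay, at which 2 of the 3 values shown sit, and one sits at the limit of > 1000000 nM in this assay, at which 1 of the 3 values shown sits; no pair of measured compounds differing in a single place is available to set the size of any step.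

Compound 4 `O=CN(O)C(CCc1cccnc1)CS(=O)(=O)N1CCN(c2ccc(Cl)cn2)CC1` differs from compound 1 by pyridin-3-yl in place of pyrimidin-2-yl on a saturated chain carbon, three bonds along the chain from an amide-type nitrogen. In this assay no step beyond the scatter is expected for this swap. Compound 4 is therefore expected to give 5000 nM, within 1500 nM to 10000 nM. The expected step is a step that the limit leaves unreadable from compound 1 to compound 4.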

Compound 4, half-maximal inhibitory concentration: < 10000 nM
Compound 4: no number, only a limit; the forecaster's own chance of this, stated with the estimate: 70%; the middle value is on the limit's open side.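

Among these compounds, compound 1 and compound 4 are both known only as limits in this assay, and no step between them can be read. The compounds shown leave open whether pyridin-3-yl in place of pyrimidin-2-yl shifts inhibition at all.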